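Methyl in Place of Acetyl on the Amine Nitrogen

The source may hold more compounds than are shown below. What is called first, only, known or untested is meant among the compounds shown, and "the series" means these compounds.

Compound 2 `COc1ccc(/C(=N\NC(C)=O)c2ccc3c(ccn3C)c2)c(OC)c1OC` carries an acetyl group on an amine nitrogen. In a functional assay on A549 cells (Homo sapiens) for cytotoxicity, read by XTT assay, with a stated time of 72 h (a higher number here means a weaker inhibitor, a lower number a stronger inhibitor), compound 2 gives > 10000 nM, which is a limit of the measurement, not a number. Compound 1 `COc1ccc(/C(=N\N)c2ccc3c(ccn3C)c2)c(OC)c1OC` carries hydrogen at that nitrogen instead. In this assay compound 1 likewise gives the limit > 10000 nM. For the measured compounds named here, the one measured step, a step that the two limits leave unreadable from compound 1 to compound 2, has no readable size, the reason being (the limit of > 10000 nM in this assay, at which 2 of the 2 values shown sit). Compound 3 `CN/N=C(/c1ccc2c(ccn2C)c1)c1ccc(OC)c(OC)c1OC` differs from compound 2 by methyl in place of acetyl on an amine nitrogen. Going by the values given here, no measured step points in either direction. Compound 3 is therefore expected to stay near the same limit, at 15000 nM, with a range from 5000 nM to 50000 nM. The step that the limit leaves unreadable from compound 2 to compound 3 is the estimate this implies.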

Compound 3, half-maximal inhibitory concentration: > 10000 nM
Compound 3: a limit, no number; the forecaster's own chance of this, stated with the estimate: 75%; the middle value lies beyond the limit too.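

For the compounds shown here, no step among compound 1, compound 2 and compound 3 can be read, because each value is a limit and not a number: the limit of > 10000 nM in this assay, at which 3 of the 3 values shown sit. In this assay, as far as these compounds go, it stays open whether hydrogen, acetyl or methyl on the amine nitrogen differ at all.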